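The source may hold more compounds than are shown below. What is called first, only, known or untested is meant among the compounds shown, and "the series" means these compounds.

Three compounds share one core and differ only in the group carried on an amine nitrogen in a ring. Compound 1 `Nc1scc(CN2CCN(c3ccc(Cl)cc3F)CC2)c1C(=O)c1ccc(Cl)cc1`, compound 2 `Nc1scc(CN2CCN(C3CCCCCC3)CC2)c1C(=O)c1ccc(Cl)cc1` and compound 3 `Nc1scc(CN2CCN(c3cccc(F)c3)CC2)c1C(=O)c1ccc(Cl)cc1` were all tested in an assay on CHO cells for displacement of a labelled ligand from adenosine receptor A3 (Homo sapiens), read by scintillation counting, with a stated time of 120 min, tested at 10 uM; a higher number here means more inhibition at the concentration tested (going by the name of the read-out), a lower number less inhibition. In that test compound 1 gives 1%, compound 2 gives 0% and compound 3 gives 4%. Compound 3 holds the largest of these three numbers, yet none of the gaps means anything: a number 3 percentage points higher from compound 1 to compound 3 (within the scatter), a number 4 percentage points higher from compound 2 to compound 3 (within the scatter), and likewise a number 1 percentage points lower from compound 1 to compound 2 (within the scatter). All three numbers sit close to the floor of what this assay can report.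

Compound 4 `Nc1scc(CN2CCN(c3ccc(F)cc3F)CC2)c1C(=O)c1ccc(Cl)cc1` is a further member of the same series. Compared with compound 3 the change is 2,4-difluorophenyl in place of 3-fluorophenyl on an amine nitrogen in a ring. Within the data shown here, every measured step so far exchanged the group on this same nitrogen, from a chlorofluorophenyl through a cycloheptyl to a fluorophenyl, and each of those steps stayed within the scatter. The present change is of the same kind, so no step beyond the scatter is expected in this assay; the expected step is a number 1 percentage points lower from compound 3 to compound 4 (within the scatter). Compound 4 is therefore estimated at 3%, with a range from 0% to 10%.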

Compound 4, a percentage reported as inhibition, at one concentration (the size of the read-out at that concentration, not a potency): 0%
For compound 4 the middle estimate is 3 percentage points above the measured one; the measured number falls inside the stated range.
By their numbers in this assay, from the lowest: compounds 2, 4, 1 and 3 (each within the scatter of the next).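

In this assay, putting 2,4-difluorophenyl in place of 3-fluorophenyl on the amine nitrogen in a ring gives a number 4 percentage points lower from compound 3 to compound 4 (within the scatter), so a second fluorine on this aromatic ring makes no readable difference. Among these compounds, compound 4 also offers the first comparison in which a single halogen is exchanged on an otherwise identical aromatic ring: fluoro in place of chloro on an aromatic carbon gives a number 1 percentage points lower from compound 1 to compound 4 (within the scatter), and the larger exchange of cycloheptyl for 2,4-difluorophenyl gives no change at the digits printed from compound 2 to compound 4 (within the scatter), so neither the halogen nor the aromatic or saturated nature of this group separates these compounds in this test. No measurement is available to explain why the numbers stay so close to the floor.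

Going by these compounds, it remains open whether a different group on this nitrogen, such as a carboxylic acid or a benzyl group, or a change elsewhere on the shared core, would give a number clear of the scatter. On these data alone, with readings this low at a single concentration, it also remains open whether these four compounds differ from one another at this receptor at all.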